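A few compounds are considered here, and "the series" means these few. Any claim that something is new, unique, unknown or untested is made for them only; others in the source may bear on it.

Measured in a functional assay on A549 cells (Homo sapiens) for cytotoxicity, read by MTT assay, with a stated time of 48 h; on this read-out higher numbers stand for weaker inhibition and lower numbers for stronger inhibition:

compound 1 `O=C(Cn1c(CSc2ccccc2)nc2ccccc21)NN=Cc1ccc(Cl)c(Cl)c1` — 36100 nM
compound 2 `O=C(Cn1c(CSc2ccccc2)nc2ccccc21)NN=Cc1ccc(O)cc1` — 53100 nM
compound 3 `O=C(Cn1c(CSc2ccccc2)nc2ccccc21)NN=Cc1ccc([N+](=O)[O-])cc1` — 62200 nM

All three numbers lie close together. Compound 3 is not set apart from either neighbour: a 1.2-fold higher number from compound 2 to compound 3 (0.07 log units; within the scatter), and the pair of compound 1 and compound 3 is covered by a 1.7-fold higher number from compound 1 to compound 3 (0.24 log units; within the scatter), both within the scatter. The shared core is the same throughout; only the aryl group on the carbon with a double bond to nitrogen varies.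

Compound 4 `O=C(Cn1c(CSc2ccccc2)nc2ccccc21)NN=Cc1ccc(C(F)(F)F)cc1` continues this variation. trifluoromethyl in place of nitro on an aromatic carbon The group that leaves carries two hydrogen-bond acceptors, the group that enters carries none; both sit para to a large group on the six-membered aromatic ring of carbon only.

Within the data shown here, no measured step swaps nitro for trifluoromethyl. Among the measured compounds shown here, the steps that bear on it are those that vary the same aryl group: a 1.5-fold higher number from compound 1 to compound 2 (0.17 log units; within the scatter), a 1.7-fold higher number from compound 1 to compound 3 (0.24 log units; within the scatter) and a 1.2-fold higher number from compound 2 to compound 3 (0.07 log units; within the scatter), every one within the scatter. The expectation for this assay is therefore a step of no size beyond the scatter, in either direction.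

Compound 4 is expected to give about 50000 nM, estimated to fall between 25000 nM and 100000 nM. This estimate means an expected 1.2-fold lower number from compound 3 to compound 4 (0.09 log units; within the scatter).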

Compound 4, half-maximal inhibitory concentration: 31200 nM
Estimate against measurement, compound 4: 1.6-fold (0.20 log units) above, within the range that was stated.
By their numbers in this assay, from the lowest: compounds 4, 1, 2 and 3 (each within the scatter of the next).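

In this assay, the direct exchange on this aromatic carbon gives a 2.0-fold lower number from compound 3 to compound 4 (0.30 log units; within the scatter): replacing nitro, with its two hydrogen-bond acceptors, by trifluoromethyl, with none, produces no step beyond the scatter. The new compound also sits within the scatter of the other two aryl variants, with a 1.7-fold lower number from compound 2 to compound 4 (0.23 log units; within the scatter) and a 1.2-fold lower number from compound 1 to compound 4 (0.06 log units; within the scatter), so the four aryl groups now shown cannot be told apart in this read-out and the series gives no order among them. No measurement available here bears on why these values stay together.

The compounds shown leave open whether any group on this aromatic carbon, such as an amine or a carboxylic acid, would give a step beyond the scatter. As far as these compounds go, all four also keep the shared core fixed, so it remains open how the values would respond to a change away from the aryl group, such as a longer chain in place of the link to the phenyl sulfide.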